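The compounds below may be only part of what the source reports. "The series", "measured", "known", "first", "only" and "open" are said of these compounds alone.

Compounds measured so far in an ADME assay on Akata cells (Homo sapiens) for cytotoxicity, with a stated time of 7 days; on this read-out lower numbers stand for higher toxicity in this test and higher numbers for lower toxicity in this test:

Compound 1, `CC(C)CSc1nc(N)nc2c1ncn2/C=C1/CC1(CO)CO`, gives a value that is a limit of the assay, > 20000 nM.
Compound 2, `CCCNc1nc(N)nc2c1ncn2/C=C1/CC1(CO)CO`, likewise gives only a limit of the assay, > 24000 nM.
Compound 3, `CCCOc1nc(N)nc2c1ncn2/C=C1/CC1(CO)CO`, also gives only a limit of the assay, > 20000 nM.

Compound 3 therefore stands at a limit, not at a number, and so do the two other compounds shown; two of the three values sit at the limit of > 20000 nM in this assay, at which 2 of the 3 values shown sit, and one at the limit of > 24000 nM in this assay, at which 1 of the 3 values shown sits. Every value is a limit. None of the steps between them can be read: a step that the two limits leave unreadable from compound 1 to compound 2, a step that the two limits leave unreadable from compound 1 to compound 3 and a step that the two limits leave unreadable from compound 2 to compound 3.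

Compound 4, `CCCCNc1nc(N)nc2c1ncn2/C=C1/CC1(CO)CO`, differs from compound 3 by butylamino in place of propoxy on an aromatic carbon. The step that bears most directly on it is a step that the two limits leave unreadable from compound 2 to compound 3, which exchanges the same two kinds of group on the same aromatic carbon, yet its size is not readable; a step that the two limits leave unreadable from compound 1 to compound 2 is equally unreadable. Within the data shown here, no measured step therefore gives a direction or a size for the change to compound 4, and no step beyond the scatter is expected in this assay.

Compound 4 is accordingly expected to remain at or beyond the limit, with an estimated value of 30000 nM, between 15000 nM and 100000 nM. The expected step that the limit leaves unreadable from compound 3 to compound 4 is estimated to be of no readable size.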

Compound 4, half-maximal cytotoxic concentration: > 24000 nM
Compound 4: a limit, no number (the forecaster's own chance of this, stated with the estimate: 85%); the middle value does not contradict the limit.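

Compound 4, like compound 1, compound 2 and compound 3, gives only a limit in this assay, so none of the steps linking compound 4 to those three compounds can be read. The compounds shown leave open at what concentration, if any, each would turn toxic in this test, and whether exchanging these groups on the aromatic carbon changes that concentration at all.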